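The compounds below may be only part of what the source reports. "The series", "measured", "known", "first", "only" and "open" are said of these compounds alone.

Of the compounds shown here, three of one series have been tested so far in an assay on isolated protein for inhibition of high affinity nerve growth factor receptor (Homo sapiens), read by HTRF, tested at 10 uM; on this read-out higher numbers stand for more inhibition at the one concentration tested (going by the name of the read-out) and lower numbers for less inhibition. Compound 1, with the structure `COC[C@@H]1CCCN1C(=O)C1CCCN1c1cc(Nc2cccc(Br)c2)ncn1`, gives 8% in this assay. Compound 2, with the structure `COC[C@@H]1CCCN1C(=O)[C@@H]1CCCN1c1cc(Nc2cccc(OC)c2)nc(N)n1`, gives 9%. Compound 3, with the structure `CN(CCCn1ccnc1)C(=O)[C@@H]1CCCN1c1nccc(Nc2ccccc2)n1`, gives 11%. Among these three numbers compound 3 gives the highest, yet the gap to compound 2 and the gap to compound 1 both lie within the usual scatter of such measurements, so none of the three can be told apart from the others on this read-out; all three show little inhibition at the single concentration tested.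

Compound 4, the structure `CN(C)CC(C)(C)CNC(=O)[C@@H]1CCCN1c1nccc(Nc2ccccc2)n1`, has not yet been measured. It differs from compound 3 in one place: (2-((dimethylamino)methyl)-2-methylpropyl)amino in place of (3-(1H-imidazol-1-yl)propyl)(methyl)amino on a carbonyl carbon. For the measured compounds named here, no pair of measured compounds differs in only one place, so there is no measured step to lean on. Because compound 3 gives 11% and the other two measured compounds sit at a similarly low level, the expectation for this change is no step beyond the scatter in either direction, a number 1 percentage points lower from compound 3 to compound 4 (within the scatter). Compound 4 is therefore estimated at 10% in this assay, expected to fall between 0% and 25%.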

Compound 4, a percentage reported as inhibition, at one concentration (the size of the read-out at that concentration, not a potency): 6%
Compound 4: middle estimate off by 4 percentage points, on the high side, within the range that was stated.
By their numbers in this assay, from the lowest: compounds 4, 1, 2 and 3 (each within the scatter of the next).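

In this assay, for the compounds shown here, putting (2-((dimethylamino)methyl)-2-methylpropyl)amino in place of (3-(1H-imidazol-1-yl)propyl)(methyl)amino on the carbonyl carbon gives a number 5 percentage points lower from compound 3 to compound 4 (within the scatter), the only one-place comparison available in this set. At this position, the two compounds therefore cannot be told apart, even though the entering group has no ring and carries one hydrogen-bond donor, while the leaving group has a five-membered aromatic ring and no donor. No measured evidence bears on this result.

The compounds shown leave open whether a morpholine ring or a longer chain ending in a carboxylic acid on this carbonyl carbon would give a step beyond the scatter. Going by these compounds alone, with only one group exchanged here, they also leave open how much this position can influence the inhibition read-out at all.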